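One Methyl on an Aromatic Oxygen, Tried on Two Cores

The source may report more compounds than this note shows. Statements on the series, on what has been measured and on what is new or still open speak of the compounds shown alone.

Compound 1 `COc1ccc2c(=O)cc(/C=C/[S+](C)[O-])oc2c1O` and compound 2 `COc1ccc2c(=O)cc(/C=C/[S+](C)[O-])oc2c1OC` share one core and differ in a single place: methyl in place of hydrogen on an oxygen on an aromatic ring. In a functional assay on DLD-1 cells (Homo sapiens) for inhibition, with a stated time of 48 h (on this read-out higher numbers stand for weaker inhibition and lower numbers for stronger inhibition), compound 1 gives only a limit of the assay, > 10000 nM, so its true value is not pinned down. In this assay compound 2 gives 3300 nM. The measured step is an at least 3.0-fold lower number from compound 1 to compound 2 (0.48 log units; beyond the scatter), and that it can only be given as a bound follows from the limit of > 10000 nM in this assay, at which 2 of the 3 values shown sit.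

Compound 3 `C[S+]([O-])/C=C/c1cc(=O)c2cc(O)ccc2o1` is built on another core; the difference between the two cores is not broken down here. In this assay compound 3 gives only a limit of the assay, > 10000 nM.

Compound 4 `COc1ccc2oc(/C=C/[S+](C)[O-])cc(=O)c2c1` is compound 3 with one alteration: methyl in place of hydrogen on an oxygen on an aromatic ring. The place of this change reads word for word as it does for the change from compound 1 to compound 2, so it is the same change carried onto a second core, and it has been measured only once among these compounds.

Among the measured compounds shown here, because the one measured instance of this change gave an at least 3.0-fold lower number from compound 1 to compound 2 (0.48 log units; beyond the scatter), compound 4 is expected to land near 8000 nM. In plain terms this expectation means an at least 1.2-fold lower number from compound 3 to compound 4 (0.09 log units; that floor lies within the scatter). Since compound 3 itself sits at a limit, the starting point is uncertain, and the estimated range for compound 4 is wide, from 2500 nM to 30000 nM, with a real chance that this assay again returns only a limit.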

Compound 4, half-maximal inhibitory concentration: 1100 nM
For compound 4 the middle estimate is 7.3-fold (0.86 log units) above the measured one, and the stated range ends above it.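

In this assay, replacing hydroxy with methoxy again goes with a lower number on the second core, an at least 9.0-fold lower number from compound 3 to compound 4 (0.95 log units; beyond the scatter), so both pairs shown point the same way and the change carries over in direction from one core to the other. The sizes of the two steps cannot be ranked, since each starts from a limit of the assay rather than from a true number: the same change on two cores in this assay, an at least 3.0-fold lower number (0.48 log units; beyond the scatter) from compound 1 to compound 2 and an at least 9.0-fold lower number (0.95 log units; beyond the scatter) from compound 3 to compound 4; the limit leaves it open whether they differ. Each step is therefore only a minimum, and two pairs do not show how large the real effect is or that it would hold on any further core, with the bound on both steps set by one ceiling: the limit of > 10000 nM in this assay, at which 2 of the 4 values shown sit.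

The compounds shown leave open whether the lower number is tied to the methyl group itself or would also appear with a longer chain on the same oxygen, such as an ethyl group, or with an amine in place of the hydroxy group. They also leave open where the true values of compound 1 and compound 3 lie, and so how far the two steps really reach.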